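A few compounds are considered here, and "the series" means these few. Any claim that something is new, unique, unknown or untested is made for them only; others in the source may bear on it.

In a toxicity assay on the whole organism (J774 cells) for cytotoxicity, with Mus musculus as the target, read by MTT assay, with a stated time of 24 h, tested at 10 uM (a lower number here means a stronger effect, a higher number a weaker effect of the compound at the concentration tested), the measured compounds are: compound 1 `CCCCCCCCCO[C@@H]1[C@@H](N)[C@@H](O[C@H]2[C@H](O)[C@@H](OCCCCCCCCC)[C@H](N)C[C@@H]2N)O[C@H](CN)[C@H]1O` with 78.4%; compound 2 `NC[C@H]1O[C@H](O[C@H]2[C@H](O)[C@@H](O)[C@H](N)C[C@@H]2N)[C@H](N)[C@@H](OCc2ccc3ccccc3c2)[C@@H]1OCc1ccc2ccccc2c1` with 79.1%; compound 3 `CCCCCCCCCO[C@@H]1[C@@H](N)[C@@H](OCC(O)CNCCCO)O[C@H](CN)[C@H]1OCCCCCCCCC` with 89.9%.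

Compound 3 stands highest of the three numbers, the weakest effect at the concentration tested. Its nearest neighbour is compound 2, a number lower by a margin beyond the scatter, and the furthest is compound 1, also lower beyond the scatter. Compound 4 `CCCCCCCCCO[C@@H]1[C@@H](N)[C@@H](OC[C@@H](O)CN)O[C@H](CN)[C@H]1OCCCCCCCCC` differs from compound 3 in one place: 2-amino-1-hydroxyethyl in place of 1-hydroxy-2-((3-hydroxypropyl)amino)ethyl on a saturated chain carbon bound to an oxygen on a saturated carbon. Among the compounds with values here, no pair of measured compounds shows this kind of change, so nothing measured tells its size. The step from compound 3 to compound 4 in this assay is expected to be a number 4.9 percentage points lower from compound 3 to compound 4 (within the scatter), a small drift downward that does not go beyond the scatter. Compound 4 is therefore estimated at 85% in this assay, with a range from 70% to 98%.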

Compound 4, a percentage reported as activity, at one concentration (the size of the read-out at that concentration, not a potency): 85.1%
Estimate against measurement, compound 4: 0.1 percentage points below, and the stated range covers the measured number.
By their numbers in this assay, from the lowest: compounds 1, 2, 4 and 3 (each within the scatter of the next, the first and the last beyond it).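

In this assay the first step measured at this place, 2-amino-1-hydroxyethyl in place of 1-hydroxy-2-((3-hydroxypropyl)amino)ethyl, reads as a number 4.8 percentage points lower from compound 3 to compound 4 (within the scatter). The two side chains therefore cannot be told apart in this read-out, so the 3-hydroxypropyl group on the nitrogen makes no difference here that exceeds the scatter. Nothing shown bears on why the two groups read alike. On these data alone, it remains open whether a guanidine or a carboxylic acid in place of the terminal amine of 3-amino-2-hydroxypropyl would read the same. As far as these compounds go, the opposite configuration at the hydroxyl-bearing carbon of that chain also remains open.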